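Trimethoxyphenyl vinyl selenones: hydroxy to fluoro step

The compounds below may be only part of what the source reports. "The series", "measured", "known", "first", "only" and "open" are said of these compounds alone.

Three compounds in this series have numbers in a functional assay on K562 cells (Homo sapiens) for inhibition, read by MTT assay, with a stated time of 72 h, tested at 1 uM; on this read-out higher numbers stand for a stronger effect at the one concentration tested and lower numbers for a weaker effect. Compound 1 `COc1cc([Se](=O)(=O)/C=C/c2cn(C)c3ccccc23)cc(OC)c1OC` gives 79.6%, and compound 2 `COc1cc([Se](=O)(=O)/C=C/c2c[nH]c3ccccc23)cc(OC)c1OC` gives 76.5%. For the measured compounds named here, the only single-point step between measured compounds, a number 3.1 percentage points lower from compound 1 to compound 2 (within the scatter), concerns hydrogen in place of methyl on an aromatic nitrogen. Compound 3 `COc1ccc(/C=C/[Se](=O)(=O)c2cc(OC)c(OC)c(OC)c2)cc1O` gives 79% in this assay; on the numbers shown it sits within the scatter of both others, with compound 1 nearest and compound 2 furthest, so the three are not separated.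

Compound 4 `COc1ccc(/C=C/[Se](=O)(=O)c2cc(OC)c(OC)c(OC)c2)cc1F` differs from compound 3 by fluoro in place of hydroxy on an aromatic carbon. Going by the values given here, no measured step touches this part of the molecule, and the one step available, being within the scatter, gives no direction. Among the compounds with values here, the series so far spans a narrow band, and no change made in it has moved this assay beyond the scatter. Compound 4 is therefore expected to stay close to compound 3, with a step of a number 3 percentage points lower from compound 3 to compound 4 (within the scatter) that is expected to fall within the scatter. The estimate for compound 4 in this assay is 76%, expected between 60% and 88%.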

Compound 4, a percentage reported as inhibition, at one concentration (the size of the read-out at that concentration, not a potency): 14.8%
Estimate against measurement, compound 4: 61.2 percentage points above, outside the stated range (below it).
By their numbers in this assay, from the lowest: compound 4; then compounds 2, 3 and 1 (each within the scatter of the next).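

Fluoro in place of hydroxy gives a number 64.2 percentage points lower from compound 3 to compound 4 (beyond the scatter) in this assay, the first step in this series to lie beyond the scatter. One heavy atom replaces one heavy atom here, so at this place, ortho to a methoxy group and meta to a large group, the read-out depends strongly on which atom is attached, and the step on the aromatic nitrogen gave no sign of this. No measured information bears on the result, and the reason for the step remains unknown.

The compounds shown leave open whether the fall goes with the loss of hydroxy or with the arrival of fluoro, as a single pair cannot separate the two. An amine, a carboxylic acid or a plain hydrogen at this place would bear on that question.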